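Swapping the bicyclic amide head and metabolic stability

The source may hold more compounds than are shown below. What is called first, only, known or untested is meant among the compounds shown, and "the series" means these compounds.

Compound 1 `O=C(NCc1ccc(S(=O)(=O)c2ccccc2)cc1)c1cc2ncccc2s1` was tested in an ADME assay on microsomes from liver (Homo sapiens) for metabolic stability, read by LC-MS, with a stated time of 30 min, tested at 1 uM (on this read-out higher numbers stand for a more stable compound and lower numbers for a less stable compound), where compound 1 gives 81%. Among the compounds with values here, of the two numbers known, this is the higher one. The other measured compound, compound 2 `O=C(NCc1ccc(S(=O)(=O)N2CCCCC2)cc1)c1cc2cnccc2s1`, differs from compound 1 in more than one place, and in this assay compound 2 gives 15%, a gap that is beyond the scatter of repeated runs. Compound 2 differs in several places at once. No single structural change can be tied to that gap.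

Compound 3 `O=C(NCc1ccc(S(=O)(=O)c2ccccc2)cc1)c1cnc2nccn2c1` has not yet been measured. It differs from compound 1 in one place: a group of 9 heavy atoms (6 carbon, 3 nitrogen; one five-membered aromatic ring with 2 hetero atoms, one six-membered aromatic ring with 2 hetero atoms) in place of a group of 9 heavy atoms (7 carbon, 1 nitrogen, 1 sulfur; one five-membered aromatic ring with 1 hetero atom, one six-membered aromatic ring with 1 hetero atom), on a carbonyl carbon. Within the data shown here, no measured pair shows the effect of a change of this kind on this assay, so the size and direction of the step are open. A modest loss is considered most likely, with the estimated step from compound 1 to compound 3 being a number 16 percentage points lower from compound 1 to compound 3 (beyond the scatter). Compound 3 is expected to give about 65%, within a range from 35% to 90%.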

Compound 3, percent of the compound remaining: 60%
The estimate for compound 3 lay 5 percentage points above the measured number, within the range that was stated.
By their numbers in this assay, from the lowest: compound 2; then compound 3; then compound 1.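

Within the data shown here, this is the first pair that differs in one place only, so a change in the number can be tied to the group on the carbonyl carbon: in this assay the swap gives a number 21 percentage points lower from compound 1 to compound 3 (beyond the scatter) with the rest of the molecule unchanged. The group on the carbonyl carbon therefore affects this read-out, and replacing the sulfur-containing bicyclic group with the one holding three nitrogens lowers the number, although compound 3 still gives 60% in this test. The data offer no explanation for the drop.

From the compounds shown here alone, this is a single swap on a single background, so it remains open whether the same swap would act alike on the other sulfonyl partner, as found in compound 2. How a plain cyclohexyl group on the carbonyl carbon would fare is also unknown.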